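The source may hold more compounds than are shown below. What is called first, only, known or untested is meant among the compounds shown, and "the series" means these compounds.

Three pyrazole-based compounds were tested in a functional assay on NCI-H226 cells (Homo sapiens) for inhibition, read by MTT assay, with a stated time of 72 h; on this read-out lower numbers stand for stronger inhibition of growth and higher numbers for weaker inhibition of growth. Compound 1 `Cc1ccc(-c2cc(/N=C/N(C)C)n(-c3cccc(Cl)c3)n2)cc1` gives 80900 nM. Compound 2 `Cc1ccc(-c2cc(/N=C/N(C)C)n(-c3ccc(Br)cc3)n2)cc1`, in this assay, gives 73900 nM. The change between them, (4-bromophenyl in place of 3-chlorophenyl on an aromatic nitrogen), produced a 1.1-fold lower number from compound 1 to compound 2 (0.04 log units; within the scatter). Compound 3 `Cc1ccc(-c2nn(-c3cccc(Cl)c3)c(N)c2C=O)cc1` gives 71800 nM in this assay; its value lies within the scatter of both compound 1 and compound 2, so no order among the three can be read. The difference between the core of compound 1 and the core of compound 3 is not broken down here.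

Compound 4 `Cc1ccc(-c2nn(-c3ccc(Br)cc3)c(N)c2C=O)cc1` has not yet been measured. It differs from compound 3 by 4-bromophenyl in place of 3-chlorophenyl on an aromatic nitrogen. This is the same kind of change as that from compound 1 to compound 2, though the surroundings differ: in compound 1 the ring atom next to the place bears a group of 5 heavy atoms, whereas in compound 3 it bears an amino group (1 heavy atom) and a formyl group sits two ring bonds away. Because a 1.1-fold lower number from compound 1 to compound 2 (0.04 log units; within the scatter) was within the scatter, a step of about a 1.1-fold lower number from compound 3 to compound 4 (0.04 log units; within the scatter) is expected. Compound 4 is therefore estimated at 66000 nM, between 30000 nM and 150000 nM.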

Compound 4, concentration for 50% growth inhibition: 8500 nM
Estimate against measurement, compound 4: 7.8-fold (0.89 log units) above, and the stated range ends above it.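

In this assay, 4-bromophenyl in place of 3-chlorophenyl on the aromatic nitrogen gave an 8.4-fold lower number from compound 3 to compound 4 (0.93 log units; beyond the scatter) on the shared core. The same change did not carry over in size from one core to the other: the same change on two cores in this assay, a 1.1-fold lower number (0.04 log units; within the scatter) from compound 1 to compound 2 and an 8.4-fold lower number (0.93 log units; beyond the scatter) from compound 3 to compound 4, 7.7-fold (0.89 log units) apart, beyond the scatter of two such steps. This shows that, among these compounds, the step seen on the core of compound 1 cannot simply be transferred to the core of compound 3, but with one pair on each core it does not show which feature of the cores matters, nor whether the change of halogen or its place on the phenyl ring accounts for the step.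

The compounds shown leave open whether the amino group or the formyl group of compound 3 and compound 4 goes with the larger step. A carboxylic acid or a nitrile in place of the formyl group, or a 4-chlorophenyl or 3-bromophenyl group on the same nitrogen, would help to separate these questions.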